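A Chloro Group Added to Compound 3

This account rests on a few compounds, and the source may have more. Where it says the series, first, only, none or still open, it means among the compounds named here.

Compound 1 `CC1(C)C2CCC1(C)C(OC(=O)/C=C/c1ccc(O)c(O)c1[N+](=O)[O-])C2` - "not determined" (no result reported)
Compound 2 `CC1(C)C2CCC1(C)C(OC(=O)/C=C/c1cc(O)c(O)c(Br)c1)C2` - "not determined" (no result reported)
Compound 3 `CC1(C)C2CCC1(C)C(OC(=O)/C=C/c1ccc(O)c(O)c1)C2` - 12000 nM

Among the measured compounds shown here, in a functional assay on SGC-7901 cells (Homo sapiens) for inhibition, read by MTT assay (on this read-out lower numbers stand for stronger inhibition and higher numbers for weaker inhibition), compound 3 gives 12000 nM, the only number available, so it cannot yet be ranked against anything. Compound 4 `CC1(C)C2CCC1(C)C(OC(=O)/C=C/c1cc(O)c(O)c(Cl)c1)C2` differs from compound 3 in one place: chloro in place of hydrogen on an aromatic carbon. This is chloro in place of hydrogen on an aromatic carbon, ortho to a hydroxy group. For the measured compounds named here, no measured pair shows what such a change does here, so the expectation is tentative. A small shift toward stronger inhibition is expected, not clearly beyond the usual scatter, and the expected step runs a 1.5-fold lower number from compound 3 to compound 4 (0.18 log units; within the scatter). For compound 4 the estimated value is 8000 nM, with an expected range of 3000 nM to 20000 nM.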

Compound 4, half-maximal inhibitory concentration: 69500 nM
The estimate for compound 4 lay 8.7-fold (0.94 log units) below the measured number, outside the stated range (above it).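

In this assay, putting chloro in place of hydrogen on this aromatic carbon, ortho to a hydroxy group, gives a 5.8-fold higher number from compound 3 to compound 4 (0.76 log units; beyond the scatter), so this change weakens inhibition by more than the usual scatter. Among the compounds shown here, this is the first measured pair, and it speaks only for this one change on the shared core. No measurement at hand explains the weakening.

From the compounds shown here alone, whether the loss is specific to chloro or would follow any group on this carbon stays open. A fluoro group or an amine at this place could separate those two possibilities.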